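This account rests on a few compounds, and the source may have more. Where it says the series, first, only, none or still open, it means among the compounds named here.

Compound 1 `CCOC(=O)C1=Cc2ccccc2OC1(OCc1cc(-c2ccc3ccccc3c2)no1)C(F)(F)F` and compound 2 `O=C(O)C1=Cc2ccccc2OC1(OCc1cc(-c2ccc3ccccc3c2)no1)C(F)(F)F` share one core and differ only at one oxygen. In a functional assay on HeLa cells (Homo sapiens) for inhibition, read by MTT assay, with a stated time of 24 h (a lower number here means a stronger inhibitor, a higher number a weaker inhibitor), compound 1 gives > 150000 nM, which is a limit of the assay rather than a number. Compound 2 likewise gives > 150000 nM, again only a limit. The step that the two limits leave unreadable from compound 1 to compound 2 is therefore unreadable, although the change itself, hydrogen in place of ethyl on an oxygen next to a carbonyl group, is a small one. Compound 1 thus stands only at a limit, and the limit of > 150000 nM in this assay, at which 2 of the 2 values shown sit, is the whole of what these two numbers show.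

Compound 3 `CCOC(=O)C1=Cc2ccccc2OC1(OCc1cc(-c2ccc(Br)cc2)no1)C(F)(F)F` differs from compound 1 in one place: 4-bromophenyl in place of naphthalen-2-yl on an aromatic carbon. Among the compounds with values here, no measured step bears on this change; the only step measured, that between compound 1 and compound 2, touches a different part of the core and is unreadable in any case. No size or direction beyond the scatter can therefore be read from the data. Compound 3 is expected to give about 150000 nM, with a range from 30000 nM to 400000 nM, most probably again only a limit. The expected step of a number no higher from compound 1 to compound 3 (the limit leaves the size open) is accordingly no more than a guess.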

Compound 3, half-maximal inhibitory concentration: 52300 nM
Compound 3: middle estimate off by 2.9-fold (0.46 log units), on the high side, within the range that was stated.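

Within the data shown here, replacing naphthalen-2-yl with 4-bromophenyl on the aromatic carbon next to the ring nitrogen gives the first readable step in this assay: an at least 2.8-fold lower number from compound 1 to compound 3 (0.45 log units; beyond the scatter). This position can therefore bring the read-out off the limit, whereas the earlier change at the oxygen next to the carbonyl group left a step that cannot be read, and compound 3 alone among the three compounds carries a number rather than a limit of the assay: the limit of > 150000 nM in this assay, at which 2 of the 3 values shown sit.
The change alters two things at once, removing one of the two aromatic carbon rings and introducing a bromine, and this single step does not separate the two.

From the compounds shown here alone, it remains open whether the step follows the loss of the second ring or the presence of the bromine, which a plain phenyl or a 4-chlorophenyl group on this same carbon could help to distinguish. Also open, going by these compounds, is whether hydrogen in place of ethyl on the oxygen next to the carbonyl group would give a readable step in this assay when the core carries 4-bromophenyl.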